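Swapping the aryl group at the ring oxygen: an expectation

The source may report more compounds than this note shows. Statements on the series, on what has been measured and on what is new or still open speak of the compounds shown alone.

In a functional assay on KB cells (Homo sapiens) for antiproliferative activity, read by sulforhodamine B assay, with a stated time of 3 days (a lower number here means that less compound is needed, a higher number that more compound is needed for the effect), the measured compounds are:
Compound 1 `CCC1=C(O)c2c(oc(-c3ccc(CC(C)C)cc3)cc2=O)C(CC)(CC)C1=O` gives 29.3 uM.
Compound 2 `CCC1=C(O)c2c(oc(-c3ccc(CBr)cc3)cc2=O)C(CC)(CC)C1=O` gives only a limit, > 46.5 uM.

Compound 2 thus stands at the assay limit (the limit of > 46.5 uM in this assay, at which 1 of the 2 values shown sits), with no number of its own. Compound 3 `CCC1=C(O)c2c(oc(-c3ccc(OC)cc3C)cc2=O)C(CC)(CC)C1=O` differs from compound 2 by 4-methoxy-2-methylphenyl in place of 4-(bromomethyl)phenyl on an aromatic carbon. Among the compounds with values here, the single measured step, an at least 1.5-fold higher number from compound 1 to compound 2 (0.20 log units; that floor lies within the scatter), concerns a different change and gives little direct guidance; it only shows that compound 1 at 29.3 uM is the one numeric anchor. The expected step is an at least 1.3-fold lower number from compound 2 to compound 3 (0.12 log units; that floor lies within the scatter). Compound 3 is estimated at 35 uM, with a range from 12 uM to 90 uM.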

Compound 3, concentration for half-maximal effect: 20.9 uM
Compound 3: the middle estimate sits 1.7-fold (0.22 log units) above what was measured, within the range that was stated.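

In this assay, 4-methoxy-2-methylphenyl in place of 4-(bromomethyl)phenyl gives an at least 2.2-fold lower number from compound 2 to compound 3 (0.34 log units; beyond the scatter). This is the only step shown that clears the scatter, so the aryl group at this position, next to the ring oxygen, can shift the read-out. The full size of the step stays unknown, since it starts from a limit for compound 2: the limit of > 46.5 uM in this assay, at which 1 of the 3 values shown sits.

The compounds shown leave open whether the methoxy or the methyl group of 4-methoxy-2-methylphenyl carries the step. They also leave open how an amine or a carboxylic acid on this aryl ring would read.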